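Removing a Methyl Group on a Seizure-Protection Scaffold

The source may hold more compounds than are shown below. What is called first, only, known or untested is meant among the compounds shown, and "the series" means these compounds.

Measured so far in a functional assay on the whole organism (Hindlimb, strain albino) with Mus musculus as the target, in the maximal electroshock model, with a stated time of 0.5 h; a higher number here means that more compound is needed for the effect, a lower number that less compound is needed:
compound 1, `O=C(/C=C/c1ccc(Cl)cc1)Nc1nc2ccccc2s1`, gives 367 umol/kg
compound 2, `CC(=O)N1N=C(Nc2nc3ccc(C)cc3s2)CC1OC1=CC=C1`, gives 160 umol/kg
compound 3, `Cc1ccc2nc(NC(=O)/C=C/c3ccc(Cl)cc3)sc2c1`, gives 152 umol/kg

Compound 3 and compound 1 differ in one place, (hydrogen in place of methyl on an aromatic carbon), and the step was a 2.4-fold higher number from compound 3 to compound 1 (0.38 log units; beyond the scatter). Compound 2 has a different core from compound 3; the difference between the two cores is not broken down here. Compound 2 and compound 3 give numbers within the usual scatter of each other, so nothing can be said about which needs less compound.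

Compound 4, `CC(=O)N1N=C(Nc2nc3ccccc3s2)CC1OC1=CC=C1`, has not yet been measured. It differs from compound 2 by hydrogen in place of methyl on an aromatic carbon. The place line reads the same word for word as for the pair of compound 3 and compound 1, so this is the same change, made on a different core. Since the step in this assay was a 2.4-fold higher number from compound 3 to compound 1 (0.38 log units; beyond the scatter), a step of about a 2.2-fold higher number from compound 2 to compound 4 (0.34 log units; beyond the scatter) is expected for compound 4, though the scatter of the assay makes the size uncertain. Compound 4 is estimated at 350 umol/kg, with a likely range from 170 umol/kg to 700 umol/kg.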

Compound 4, dose for half-maximal effect: 382 umol/kg
For compound 4 the middle estimate is 1.1-fold (0.04 log units) below the measured one; the measured number falls inside the stated range.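

In this assay, putting hydrogen in place of methyl on the aromatic carbon gave a 2.4-fold higher number from compound 2 to compound 4 (0.38 log units; beyond the scatter), so more of compound 4 is needed for the effect. Set beside the earlier example, the same change moved the number by a matching amount on both cores: the same change on two cores in this assay, a 2.4-fold higher number (0.38 log units; beyond the scatter) from compound 3 to compound 1 and a 2.4-fold higher number (0.38 log units; beyond the scatter) from compound 2 to compound 4, 1.0-fold (0.00 log units) apart, within the scatter of two such steps This shows that, for these two pairs, the step carried over from one core to the other; it does not show that the step would carry over to any further core, nor does it explain why the methyl group makes this difference.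

The compounds shown have only methyl or hydrogen at this place, so it remains open how a larger alkyl group such as ethyl, or an oxygen-linked group such as methoxy, would compare there. Also open, from the compounds shown here alone, is whether methyl on a different carbon of the same ring would give a similar step.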